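Fluoro for methoxy on the core of compound 1

The source may hold more compounds than are shown below. What is called first, only, known or untested is meant among the compounds shown, and "the series" means these compounds.

Measured so far:
compound 1, `COc1ccc(C2Nc3cccc(OC)c3C(=O)N2Cc2ccccc2)cc1COc1ccc(NC(C)=O)cc1`: 4480 nM
compound 2, `COc1ccc(C2Nc3ccc(O)cc3C(=O)N2Cc2ccccc2)cc1COc1ccc(NC(C)=O)cc1`: 330 nM

Both compounds were tested in a functional assay on HEK-EM293 cells for agonist activity at Thyrotropin receptor (Homo sapiens), read by ELISA and cAMP accumulation, with a stated time of 1 h; a lower number here means that less compound is needed, a higher number that more compound is needed for the effect. Compound 1 gives 4480 nM and stands at the highest of the two numbers. Compound 2 gives 330 nM, a lower number that lies beyond the usual scatter, but the two compounds differ in more than one place, so their values alone do not show what any single change does.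

Compound 3, `COc1ccc(C2Nc3cccc(F)c3C(=O)N2Cc2ccccc2)cc1COc1ccc(NC(C)=O)cc1`, has not been measured yet. It is made from compound 1 by one change: fluoro in place of methoxy on an aromatic carbon. Among the compounds with values here, no measured pair shows this change, so the step from compound 1 to compound 3 cannot be read off any data here. The step of a 1.1-fold lower number from compound 1 to compound 3 (0.05 log units; within the scatter) is expected to stay within the scatter, in no definite direction. For compound 3 the expected value in this assay is 4000 nM, with a range from 1200 nM to 13000 nM.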

Compound 3, half-maximal effective concentration: 280 nM
The estimate for compound 3 lay 14-fold (1.15 log units) above the measured number, and the stated range ends above it.
By their numbers in this assay, from the lowest: compounds 3 and 2 (each within the scatter of the next); then compound 1.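

In this assay replacing methoxy by fluoro on this aromatic carbon of the shared core gives a 16-fold lower number from compound 1 to compound 3 (1.20 log units; beyond the scatter). Within the data shown here, this is the first direct sign that the group on this carbon matters for the effect, as compound 1 and compound 2 differ in more than one place and could not isolate any single change. No measurement given here bears on what lies behind the step.

On these data alone, what remains open is whether the result comes from losing methoxy or from gaining fluoro, and a plain hydrogen, a chlorine or an amine on the same carbon would help to separate the two. It is also unknown whether the same swap would give a step of similar size with other groups elsewhere on the core.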